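A few compounds are considered here, and "the series" means these few. Any claim that something is new, unique, unknown or untested is made for them only; others in the source may bear on it.

Of the compounds shown here, three have so far been tested in an ADME assay on HepG2 cells (Homo sapiens) for cytotoxicity, read by neutral red uptake, with a stated time of 48 h; on this read-out lower numbers stand for stronger inhibition and higher numbers for weaker inhibition. Compound 1 `CCN1CCN(c2nc(C)cc(NCCCCNc3ccnc4cc(Cl)ccc34)n2)CC1` gives 15400 nM. Compound 2 `Cc1cc(Cl)nc(NCCCCCCNc2ccnc3cc(Cl)ccc23)n1` gives 8100 nM, and compound 3 `Cc1cc(NCCCNc2ccnc3cc(Cl)ccc23)nc(N2CCN(C)CC2)n1` gives 26700 nM. The number for compound 1 lies within the usual scatter of repeated measurements from each of the other two, so neither gap can be read as a real difference.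

The compound still to be tested, compound 4 `Cc1cc(NCCCCNc2ccnc3cc(Cl)ccc23)nc(N2CCN(C)CC2)n1`, differs from compound 1 in one place: hydrogen in place of methyl on a saturated chain carbon bound to an amine nitrogen in a ring. In words, hydrogen takes the place of methyl on a saturated chain carbon bound to an amine nitrogen in a ring, which turns 4-ethylpiperazin-1-yl into 4-methylpiperazin-1-yl. Among the compounds with values here, no two tested compounds differ in one place only, so the data offer no direct measure of what such a change does. No step beyond the scatter is expected in this assay. Compound 3 also carries 4-methylpiperazin-1-yl and gives 26700 nM, a number that offers no reason to expect a large step. The expected step runs a 1.2-fold higher number from compound 1 to compound 4 (0.07 log units; within the scatter). The estimate for compound 4 is 18000 nM, with an expected range from 9000 nM to 36000 nM.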

Compound 4, half-maximal inhibitory concentration: 29500 nM
Compound 4: middle estimate off by 1.6-fold (0.21 log units), on the low side; measured number inside the range.
By their numbers in this assay, from the lowest: compounds 2, 1, 3 and 4 (each within the scatter of the next, the first and the last beyond it).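

This pair is the first among the compounds shown to differ in one place only, so it gives a direct reading of what happens when 4-ethylpiperazin-1-yl becomes 4-methylpiperazin-1-yl, with hydrogen in place of methyl on a saturated chain carbon bound to an amine nitrogen in a ring. In this assay this change gives a 1.9-fold higher number from compound 1 to compound 4 (0.28 log units; within the scatter) and so cannot be told apart from the differences seen between repeated measurements. Nothing in the data bears on why the result came out this way.

The compounds shown leave open whether a larger group at this place, such as a benzyl group, or a more different one, such as a carboxylic acid on the end of a longer chain, would give a real step in this assay. On these data alone, this is also a single pair, so it remains unknown whether ethyl and methyl would read as closely on a compound with a different chain linking the two halves of the molecule.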